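Estimating half-life after a side-chain swap on the core

This account rests on a few compounds, and the source may have more. Where it says the series, first, only, none or still open, it means among the compounds named here.

Measured so far in an ADME assay (liver, Mus musculus) for metabolic stability, using microsomes; on this read-out lower numbers stand for a shorter-lived compound and higher numbers for a longer-lived compound
Compound 1 `C=CC(=O)Nc1cccc(CNc2nc(Nc3cnn(C(F)F)c3)ncc2Cl)c1` gives 0.173 h
Compound 2 `C=CC(=O)Nc1cccc(CNc2nc(Nc3cnn(C4CCN(C(C)=O)CC4)c3)ncc2Cl)c1` gives 0.05 h
Compound 3 `C=CC(=O)Nc1cccc(CNc2nc(Nc3cnn(CCN(C)C)c3)ncc2Cl)c1` gives 0.03 h

Compound 3 (0.03 h) sits at the short-lived end of this small set. Its gap to the nearest neighbour is a 1.7-fold lower number from compound 2 to compound 3 (0.22 log units; within the scatter), so those two cannot be ranked, while a 5.8-fold lower number from compound 1 to compound 3 (0.76 log units; beyond the scatter) is a real difference.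

Among the compounds with values here, compound 4 `C=CC(=O)Nc1cccc(CNc2nc(Nc3cnn(C(C)(C)COC)c3)ncc2Cl)c1` keeps the shared core and changes only one group (1-(methoxymethyl)-1-methylethyl in place of 2-(dimethylamino)ethyl on an aromatic nitrogen). It carries 1-(methoxymethyl)-1-methylethyl in place of 2-(dimethylamino)ethyl on an aromatic nitrogen.

No measurement covers this entering group. The only guide is what other swaps at this place did, namely a 3.5-fold lower number from compound 1 to compound 2 (0.54 log units; beyond the scatter) and the modest step to compound 3 shown above. Such swaps moved the number only modestly, and compound 3 starts at the bottom of the range, so a small upward move in this assay is the likeliest outcome.

The expected change is a 2.0-fold higher number from compound 3 to compound 4 (0.30 log units; within the scatter), and this is only an estimate.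

For compound 4 the estimated half-life is 0.06 h, with an expected range from 0.03 h to 0.14 h.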

Compound 4, half-life: 0.03 h
Estimate against measurement, compound 4: 2.0-fold (0.30 log units) above, within the range that was stated.
By their numbers in this assay, from the lowest: compounds 3, 4 and 2 (each within the scatter of the next); then compound 1.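

In this assay the change from 2-(dimethylamino)ethyl, which holds a nitrogen, to 1-(methoxymethyl)-1-methylethyl, which holds an oxygen instead, gives no change at the digits printed from compound 3 to compound 4 (within the scatter) at this place on the aromatic nitrogen. Compound 4 also cannot be separated from the compound carrying 1-acetylpiperidin-4-yl, with a 1.7-fold lower number from compound 2 to compound 4 (0.22 log units; within the scatter) on record, whereas a 5.8-fold lower number from compound 1 to compound 4 (0.76 log units; beyond the scatter) shows that three differently built side chains now sit together, apart from difluoromethyl in compound 1. No measured evidence here explains why these three side chains fall so close together. From the compounds shown here alone, it remains open whether another small group on this nitrogen, such as a methyl or a trifluoromethyl, would stay close to compound 1. A carboxylic acid or a longer ether chain at this place is also untested among the compounds shown.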